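Aryl ether macrolides: methyl removal on the phenoxy group

A few compounds are considered here, and "the series" means these few. Any claim that something is new, unique, unknown or untested is made for them only; others in the source may bear on it.

Compound 1 `CC[C@@H]1/C=C(\C)C[C@H](C)C[C@H](OC)[C@H]2O[C@@](O)(C(=O)C(=O)N3CCCC[C@H]3C(=O)O[C@H](/C(C)=C/[C@@H]3CC[C@@H](Oc4ccccc4)[C@H](OC)C3)[C@H](C)[C@@H](O)CC1=O)[C@H](C)C[C@@H]2OC` carries a phenoxy group on the shared core; in a functional assay on cells for inhibition, with Murine T-cell line (Mus musculus) as the target (a higher number here means a weaker inhibitor, a lower number a stronger inhibitor), compound 1 gives 5.4 nM. Compound 2 `CC[C@@H]1/C=C(\C)C[C@H](C)C[C@H](OC)[C@H]2O[C@@](O)(C(=O)C(=O)N3CCCC[C@H]3C(=O)O[C@H](/C(C)=C/[C@@H]3CC[C@@H](Oc4ccc(C)cc4)[C@H](OC)C3)[C@H](C)[C@@H](O)CC1=O)[C@H](C)C[C@@H]2OC` carries a 4-methylphenoxy group instead, and in this assay compound 2 gives 2.7 nM. The change from compound 2 to compound 1 is hydrogen in place of methyl on an aromatic carbon and the step it made is a 2.0-fold higher number from compound 2 to compound 1 (0.30 log units; within the scatter). Compound 3 `CC[C@@H]1/C=C(\C)C[C@H](C)C[C@H](OC)[C@H]2O[C@@](O)(C(=O)C(=O)N3CCCC[C@H]3C(=O)O[C@H](/C(C)=C/[C@@H]3CC[C@@H](O)[C@H](Oc4ccc(C)cc4)C3)[C@H](C)[C@@H](O)CC1=O)[C@H](C)C[C@@H]2OC` also carries a 4-methylphenoxy group, but its core differs from that of compound 2 in a way that is not broken down here; in this assay compound 3 gives 2.6 nM, which sits within the scatter of compound 2.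

Compound 4 `CC[C@@H]1/C=C(\C)C[C@H](C)C[C@H](OC)[C@H]2O[C@@](O)(C(=O)C(=O)N3CCCC[C@H]3C(=O)O[C@H](/C(C)=C/[C@@H]3CC[C@@H](O)[C@H](Oc4ccccc4)C3)[C@H](C)[C@@H](O)CC1=O)[C@H](C)C[C@@H]2OC` is derived from compound 3 by hydrogen in place of methyl on an aromatic carbon. This is the same change as from compound 2 to compound 1, at a place described in identical terms. Going by the values given here, the expected step is a 2.0-fold higher number from compound 3 to compound 4 (0.30 log units; within the scatter), resting on the single earlier example, a 2.0-fold higher number from compound 2 to compound 1 (0.30 log units; within the scatter), and on the observation that compound 3 and compound 2 give numbers within the scatter of each other. Among the compounds with values here, compound 4 is therefore estimated at 5.2 nM, with the range 2.5 nM to 11 nM reflecting that only one prior step supports the expectation.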

Compound 4, half-maximal inhibitory concentration: 3.2 nM
The estimate for compound 4 lay 1.6-fold (0.21 log units) above the measured number; low and high end bracket the measured number.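

In this assay, going from 4-methylphenoxy to phenoxy on the core of compound 3 gives a 1.2-fold higher number from compound 3 to compound 4 (0.09 log units; within the scatter) and so stays within the scatter, as it did on the core of compound 2. Set side by side, the two steps do not differ: the same change on two cores in this assay, a 2.0-fold higher number (0.30 log units; within the scatter) from compound 2 to compound 1 and a 1.2-fold higher number (0.09 log units; within the scatter) from compound 3 to compound 4, 1.6-fold (0.21 log units) apart, within the scatter of two such steps. This shows that the change carries across these two cores without a detectable difference in step size, but it does not show a real effect of the methyl group on either core, and two cores cannot speak for the whole series.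

The compounds shown hold only hydrogen and methyl at this place on the aromatic ring, so a wider range of groups remains to be read. Going by these compounds, whether an amine, a carboxylic acid or a longer chain on that aromatic carbon, para to a large group, would give a step beyond the scatter stays open, as does whether such a step would carry from one core to the other.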